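This account rests on a few compounds, and the source may have more. Where it says the series, first, only, none or still open, it means among the compounds named here.

In a functional assay on HCT-116 cells (Homo sapiens) for inhibition, read by CCK-8 assay, with a stated time of 72 h, tested at 8 uM (on this read-out higher numbers stand for more inhibition of growth at the one concentration tested and lower numbers for less inhibition of growth), compound 2 (`Nc1ccccc1NC(=O)/C=C/c1ccc(CSCCc2ccccc2)cc1`) gives 10.6% and compound 1 (`Cc1cc(C)cc(SCc2ccc(/C=C/C(=O)Nc3ccccc3N)cc2)c1`) gives 4.2% on the same read-out. Among the compounds with values here, the two therefore stand together within the usual scatter, and compound 2 has no real distance from its only measured neighbour. The next structure, compound 3 (`CC(C)(C)c1ccc(SCc2ccc(/C=C/C(=O)Nc3ccccc3N)cc2)cc1`), keeps the shared core and carries 4-(tert-butyl)phenyl in place of phenethyl on a sulfur. Within the data shown here, only one measured step bears on this change, the exchange of 3,5-dimethylphenyl for phenethyl on that same sulfur (a number 6.4 percentage points higher from compound 1 to compound 2 (within the scatter)), and it stays within the scatter. Among the measured compounds shown here, compound 3 resembles compound 1 in bearing a substituted phenyl group on the sulfur, but no measured compound yet carries the tert-butyl group, so the data leave real uncertainty. For the measured compounds named here, with so small a step as the only guide, no change beyond the scatter is expected in this assay, and the estimated step is slight (a number 1.6 percentage points lower from compound 2 to compound 3 (within the scatter)). Compound 3 is estimated at 9% (expected range 0% to 25%).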

Compound 3, percent growth inhibition at one concentration: 39%
Estimate against measurement, compound 3: 30 percentage points below; measured number outside the range, above it.
By their numbers in this assay, from the lowest: compounds 1 and 2 (each within the scatter of the next); then compound 3.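

In this assay, the group on the sulfur now separates compounds beyond the scatter: 4-(tert-butyl)phenyl in place of phenethyl gives a number 28.4 percentage points higher from compound 2 to compound 3 (beyond the scatter) and 4-(tert-butyl)phenyl in place of 3,5-dimethylphenyl gives a number 34.8 percentage points higher from compound 1 to compound 3 (beyond the scatter). The earlier pair had shown no real difference at this position, and compound 3 shows that the position can respond to the group placed there; a substituted phenyl on the sulfur is not enough on its own, as compound 1 carries one and stays within the scatter of compound 2. Nothing in the data shown accounts for the difference between these groups.

On these data alone, what remains open is whether the tert-butyl group itself matters or whether other groups on the same sulfur, such as plain phenyl, cyclohexyl, or a phenyl ring carrying an amine or a carboxylic acid, would match compound 3. A reading at a single concentration also leaves open how the compounds would compare across a range of concentrations.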